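Hydroxy for Sulfonyl Ester: Expecting a Fourth Limit

A few compounds are considered here, and "the series" means these few. Any claim that something is new, unique, unknown or untested is made for them only; others in the source may bear on it.

Compound 1 `Cc1c(O)ccc2c1[C@H](Cn1cc(-c3ccc(Cl)cc3)nn1)[C@@]13CC(=O)[C@@](C)(CC[C@@H]21)C3`: in a functional assay on MCF7 cells (Homo sapiens) for cytotoxicity, read by MTT assay, with a stated time of 4 days (a lower number here means a stronger inhibitor, a higher number a weaker inhibitor), compound 1 gives > 20000 nM, which is a limit of the assay rather than a number.
Compound 2 `Cc1ccc(S(=O)(=O)Oc2ccc3c(c2C)[C@H](Cn2cc(-c4ccc(Cl)cc4)nn2)[C@@]24CC(=O)[C@@](C)(CC[C@@H]32)C4)cc1`: in this assay compound 2 gives > 20000 nM, also a limit.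
Compound 3 `Cc1ccc(S(=O)(=O)Oc2ccc3c(c2C)[C@H](Cn2cc(-c4ccccn4)nn2)[C@@]24CC(=O)[C@@](C)(CC[C@@H]32)C4)cc1`: in this assay compound 3 gives > 20000 nM, again a limit.

Going by the values given here, every value so far rests at the limit of > 20000 nM in this assay, at which 3 of the 3 values shown sit, so no step between these compounds can be read. From compound 2 to compound 1 the change is hydrogen in place of (4-methylphenyl)sulfonyl on an oxygen on an aromatic ring, and the step is a step that the two limits leave unreadable from compound 2 to compound 1. Compound 4 `Cc1c(O)ccc2c1[C@H](Cn1cc(-c3ccccn3)nn1)[C@@]13CC(=O)[C@@](C)(CC[C@@H]21)C3`, not yet measured, arises from compound 3 by the same change at the same place, (hydrogen in place of (4-methylphenyl)sulfonyl on an oxygen on an aromatic ring). The cores of compound 2 and compound 3 differ by pyridin-2-yl in place of 4-chlorophenyl on an aromatic carbon. Because the limit of > 20000 nM in this assay, at which 3 of the 3 values shown sit, holds for every value shown, the expected step is a step that the limit leaves unreadable from compound 3 to compound 4, set beside the unreadable a step that the two limits leave unreadable from compound 2 to compound 1. Compound 4 is therefore estimated at about 30000 nM in this assay, most likely reported once more only as a limit.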

Compound 4, half-maximal inhibitory concentration: > 20000 nM
Compound 4 gave a limit, no number (the forecaster's own chance of this, stated with the estimate: 85%); the middle value is on the limit's open side.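

Compound 4 gives a limit and no number, so neither new step, from compound 3 to compound 4 or from compound 1 to compound 4, can be read: the limit of > 20000 nM in this assay, at which 4 of the 4 values shown sit.

The compounds shown leave open how far each one lies beyond that limit in this assay.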